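From Methoxy to Nitro in a Paw Edema Series

This account rests on a few compounds, and the source may have more. Where it says the series, first, only, none or still open, it means among the compounds named here.

Compound 1 `CCOC(=O)Cc1nc(N)n(C(=O)c2ccc(Cl)cc2)n1`: 42.3%
Compound 2 `CCOC(=O)Cc1nc(N)n(C(=O)c2ccc(Br)cc2)n1`: 43%
Compound 3 `CCOC(=O)Cc1nc(N)n(C(=O)c2ccc(OC)cc2)n1`: 41.5%

All three were tested in a functional assay on the whole organism (strain albino) for inhibition, with Rattus norvegicus as the target, read by paw edema, with stated times of 30 min and 2 h, at a dose of 5 mg/kg by the oral route; on this read-out higher numbers stand for more inhibition at the one dose given (going by the name of the read-out) and lower numbers for less inhibition. Compound 3 holds the lowest of the three numbers, yet the steps leading to it, a number 0.8 percentage points lower from compound 1 to compound 3 (within the scatter) and a number 1.5 percentage points lower from compound 2 to compound 3 (within the scatter), both lie within the scatter, so the three compounds cannot be told apart on this read-out. Compound 4 `CCOC(=O)Cc1nc(N)n(C(=O)c2ccc([N+](=O)[O-])cc2)n1` has not been measured. Its change from compound 3 is nitro in place of methoxy on an aromatic carbon. The measured steps that exchange the group on that aromatic carbon, a number 0.7 percentage points higher from compound 1 to compound 2 (within the scatter), a number 0.8 percentage points lower from compound 1 to compound 3 (within the scatter) and a number 1.5 percentage points lower from compound 2 to compound 3 (within the scatter), all stay within the scatter. Compound 4 is therefore expected to give a step of a number 0.5 percentage points higher from compound 3 to compound 4 (within the scatter), no shift beyond the scatter. Compound 4 is estimated at 42%, between 31% and 53%.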

Compound 4, a percentage reported as inhibition, in the whole organism at one dose (the size of the read-out at that dose, not a potency): 46.3%
For compound 4 the middle estimate is 4.3 percentage points below the measured one, and the stated range covers the measured number.
By their numbers in this assay, from the lowest: compounds 3, 1, 2 and 4 (each within the scatter of the next).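

Nitro in place of methoxy, bromo or chloro gives a number 4.8 percentage points higher from compound 3 to compound 4 (within the scatter) and a number 3.3 percentage points higher from compound 2 to compound 4 (within the scatter) and a number 4 percentage points higher from compound 1 to compound 4 (within the scatter) in this assay and so stays within the scatter of all three other groups. This aromatic carbon, para to a large group, thus takes a group of three heavy atoms with a double bond outside aromatic rings without a shift beyond the scatter. No available evidence bears on this result. On these data alone, whether an amine, a carboxylic acid or a longer chain on this carbon would move the number beyond the scatter stays open.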